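The compounds below may be only part of what the source reports. "The series", "measured", "known", "first", "only" and "open" are said of these compounds alone.

Of the compounds shown here, three sharing one core have been measured. Compound 1 `CN(C)CCn1cnnc1-c1cc(Oc2ccc(NC(=O)N/N=C/c3ccc(Cl)cc3Cl)cc2F)ccn1` gives 130 nM in a functional assay on NCI-H460 cells (Homo sapiens) for cytotoxicity, read by MTT assay, with a stated time of 72 h; on this read-out higher numbers stand for weaker inhibition and lower numbers for stronger inhibition. Compound 2 `CN(C)CCn1cnnc1-c1cc(Oc2ccc(NC(=O)N/N=C/c3ccc(O)c(Br)c3)cc2F)ccn1` gives 430 nM in this assay, standing second highest of the three numbers. Compound 3 `CN(C)CCn1cnnc1-c1cc(Oc2ccc(NC(=O)N/N=C/c3ccc(F)cc3)cc2F)ccn1` gives 1980 nM in this assay. The steps are a 3.3-fold higher number from compound 1 to compound 2 (0.52 log units; beyond the scatter), a 4.6-fold higher number from compound 2 to compound 3 (0.66 log units; beyond the scatter) and a 15-fold higher number from compound 1 to compound 3 (1.18 log units; beyond the scatter); each exchanges the whole aryl group, so none tests a single halogen swap. Compound 4 `CN(C)CCn1cnnc1-c1cc(Oc2ccc(NC(=O)N/N=C/c3ccc(O)c(F)c3)cc2F)ccn1` differs from compound 2 by fluoro in place of bromo on an aromatic carbon, on the same aryl ring. Within the data shown here, with no step of this kind measured, compound 4 is expected to lie close to compound 2, with a 1.4-fold higher number from compound 2 to compound 4 (0.14 log units; within the scatter) as the estimated step, likely within the scatter. Compound 4 is therefore expected to give about 600 nM in this assay, between 250 nM and 1500 nM.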

Compound 4, half-maximal inhibitory concentration: 2620 nM
For compound 4 the middle estimate is 4.4-fold (0.64 log units) below the measured one; the measured number lies above the stated range.
By their numbers in this assay, from the lowest: compound 1; then compound 2; then compounds 3 and 4 (each within the scatter of the next).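

Within this assay, fluoro in place of bromo ortho to the hydroxy group costs activity (a 6.1-fold higher number from compound 2 to compound 4 (0.78 log units; beyond the scatter)), so this single halogen exchange counts for more than the whole-ring exchanges could show. The 3-fluoro-4-hydroxyphenyl ring stands level with 4-fluorophenyl (a 1.3-fold higher number from compound 3 to compound 4 (0.12 log units; within the scatter)) and far from 2,4-dichlorophenyl (a 20-fold higher number from compound 1 to compound 4 (1.30 log units; beyond the scatter)). No measurement at hand explains the loss.

From the compounds shown here alone, whether chloro or iodo at this position would keep the activity of compound 2 remains open. So does the effect of a methoxy group in place of the hydroxy group.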